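Trifluoromethyl in Place of a Larger Fluorinated Group

This account rests on a few compounds, and the source may have more. Where it says the series, first, only, none or still open, it means among the compounds named here.

In a functional assay on CWR22R cells (Homo sapiens) for antiproliferative activity, read by propidium iodide staining, with a stated time of 96 h (a higher number here means a weaker inhibitor, a lower number a stronger inhibitor), compound 1 `CC(O)(CSc1ccc(S(F)(F)(F)(F)F)cc1)C(=O)Nc1cccc(S(F)(F)(F)(F)F)c1` gives 13100 nM, and compound 2 `CC(O)(CSc1ccc(C(F)(F)F)cc1)C(=O)Nc1cccc(S(F)(F)(F)(F)F)c1` gives 26900 nM. The change between them is a group of 4 heavy atoms (1 carbon, 3 fluorine; no ring) in place of a group of 6 heavy atoms (5 fluorine, 1 sulfur; no ring), on an aromatic carbon, and it brought a 2.1-fold higher number from compound 1 to compound 2 (0.31 log units; beyond the scatter). Compound 3 `CC(O)(COc1cccc(S(F)(F)(F)(F)F)c1)C(=O)Nc1ccc(S(F)(F)(F)(F)F)cc1` gives 17600 nM in this assay; how its core differs from the core of compound 1 is not broken down here. Compound 4 `CC(O)(COc1cccc(C(F)(F)F)c1)C(=O)Nc1ccc(S(F)(F)(F)(F)F)cc1` is not yet measured and carries the same kind of change, (a group of 4 heavy atoms (1 carbon, 3 fluorine; no ring) in place of a group of 6 heavy atoms (5 fluorine, 1 sulfur; no ring), on an aromatic carbon), though here the place is meta to a large group rather than para to a large group. A step of similar size is expected, a 2.0-fold higher number from compound 3 to compound 4 (0.30 log units; within the scatter), because the measured step of a 2.1-fold higher number from compound 1 to compound 2 (0.31 log units; beyond the scatter) was modest yet beyond the scatter. Compound 4 is therefore estimated at 35000 nM, expected to fall between 15000 nM and 80000 nM.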

Compound 4, half-maximal inhibitory concentration: 14600 nM
Beside the measured number, compound 4's estimate is 2.4-fold (0.38 log units) above it; measured number below the stated range.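

Replacing the larger fluorinated group with trifluoromethyl on the core of compound 3 gave a 1.2-fold lower number from compound 3 to compound 4 (0.08 log units; within the scatter) in this assay, so on this core the swap produced no change that can be told from the scatter. Set beside the step on the core of compound 1, the two results cannot be separated: the same change on two cores in this assay, a 2.1-fold higher number (0.31 log units; beyond the scatter) from compound 1 to compound 2 and a 1.2-fold lower number (0.08 log units; within the scatter) from compound 3 to compound 4, 2.5-fold (0.39 log units) apart, within the scatter of two such steps. This is consistent with the change carrying over from one core to the other, but two small steps show neither that its effect is the same on both cores nor that it differs.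

The compounds shown leave open how other groups at this place, such as a nitrile, a chlorine atom or an amine, would compare. They also leave open whether the same swap would behave similarly on further cores.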